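Swapping a difluorophenyl for a methylphenyl group

The compounds below may be only part of what the source reports. "The series", "measured", "known", "first", "only" and "open" are said of these compounds alone.

Among the compounds with values here, compound 2 `Cc1cc(C(=O)O)nn1Cc1cc(Br)ccc1OCc1c(F)cccc1F` gives 105 nM in a functional assay on CHO-K1 cells for antagonist activity at prostaglandin E2 receptor EP1 subtype (Homo sapiens), read by FLIPR (a higher number here means a weaker inhibitor, a lower number a stronger inhibitor), the higher of the two numbers so far; compound 1 `Cc1cc(C(=O)O)nn1Cc1cc(Br)ccc1OCc1ccc(F)cc1F` gives 2.63 nM. Within the data shown here, the only measured step is a 40-fold higher number from compound 1 to compound 2 (1.60 log units; beyond the scatter). Compound 3 `Cc1cccc(COc2ccc(Br)cc2Cn2nc(C(=O)O)cc2C)c1` carries 3-methylphenyl in place of 2,6-difluorophenyl on a saturated chain carbon bound to an oxygen on an aromatic ring. Among the measured compounds shown here, since the one known step shows that the arrangement on this ring matters greatly, and compound 3 moves away from the arrangement of compound 2 toward a ring carrying neither fluorine, a step of a 7.0-fold lower number from compound 2 to compound 3 (0.85 log units; beyond the scatter) is expected. Compound 3 is therefore estimated at 15 nM, between 3 nM and 80 nM.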

Compound 3, inhibition constant: 525 nM
Beside the measured number, compound 3's estimate is 35-fold (1.54 log units) below it; the measured number lies above the stated range.
By their numbers in this assay, from the lowest: compound 1; then compound 2; then compound 3.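

In this assay the 3-methylphenyl group gives a 5.0-fold higher number from compound 2 to compound 3 (0.70 log units; beyond the scatter) and a 200-fold higher number from compound 1 to compound 3 (2.30 log units; beyond the scatter) so compound 3 is the weakest inhibitor of the three. On this saturated chain carbon, then, a ring carrying one methyl and no fluorine falls short of both difluorophenyl rings, and the 2,6-difluorophenyl ring of compound 2 stands closer to it than to the 2,4-difluorophenyl ring of compound 1. Nothing available explains these differences.

On these data alone, compound 3 both removes the fluorines and adds a methyl, so the share of each change remains open. A plain phenyl or a 4-methylphenyl group at this place could begin to separate them.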